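A few compounds are considered here, and "the series" means these few. Any claim that something is new, unique, unknown or untested is made for them only; others in the source may bear on it.

Values from an ADME assay on HeLa cells (Homo sapiens) for cytotoxicity, read by MTT assay (a lower number here means a stronger inhibitor, a higher number a weaker inhibitor), for the compounds measured so far
- compound 1 `COC(=O)CNC(=O)CCC(=O)Oc1ccc(C[C@H]2C(=O)OC[C@@H]2Cc2ccc(OC)c(OC)c2)cc1OC` gives 179000 nM
- compound 2 `COc1ccc(C[C@H]2COC(=O)[C@@H]2Cc2ccc(OCC(=O)N3CCCCC3)c(OC)c2)cc1OC` gives 293000 nM

Within the data shown here, only two numbers are available, so compound 1 can be placed against just one neighbour. The gap between them is a 1.6-fold higher number from compound 1 to compound 2 (0.21 log units; within the scatter) and so the two cannot be ranked.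

The next compound to be measured is compound 3 `COC(=O)[C@@H](NC(=O)CCC(=O)Oc1ccc(C[C@H]2C(=O)OC[C@@H]2Cc2ccc(OC)c(OC)c2)cc1OC)C(C)C`. It differs from compound 1 by a single change isopropyl in place of hydrogen on a saturated chain carbon bound to an amide-type nitrogen and a carbonyl carbon with isopropyl in place of hydrogen on a saturated chain carbon bound to an amide-type nitrogen and a carbonyl carbon. Put another way, (methoxycarbonyl)methyl becomes 1-(methoxycarbonyl)-2-methylpropyl.

Among the measured compounds shown here, no measured pair tests this change directly, and one step is a thin guide. For the measured compounds named here, the only evidence is that replacing the whole group on an oxygen on an aromatic ring gave a 1.6-fold higher number from compound 1 to compound 2 (0.21 log units; within the scatter) and did not move the number beyond the scatter. A similarly small result is expected here, with the estimated step being a 1.1-fold lower number from compound 1 to compound 3 (0.02 log units; within the scatter). Compound 3 is expected near 170000 nM with an estimated range from 80000 nM to 350000 nM.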

Compound 3, half-maximal inhibitory concentration: 64000 nM
Compound 3: middle estimate off by 2.7-fold (0.42 log units), on the high side; measured number below the stated range.
By their numbers in this assay, from the lowest: compound 3; then compounds 1 and 2 (each within the scatter of the next).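

In this assay, isopropyl in place of hydrogen on a saturated chain carbon bound to an amide-type nitrogen and a carbonyl carbon gives a 2.8-fold lower number from compound 1 to compound 3 (0.45 log units; beyond the scatter) and this modest step lies beyond the scatter. The earlier pair replaced a whole group on an oxygen on an aromatic ring and could not be ranked, whereas here a smaller edit, adding just three carbons to turn (methoxycarbonyl)methyl into 1-(methoxycarbonyl)-2-methylpropyl, does move the number, so this position is not indifferent to what it carries. The data shown offer no measurement that explains the drop.

From the compounds shown here alone, with only isopropyl to go on, it remains open whether the size of the step follows the size of the group, which a smaller methyl or a larger benzyl at the same carbon would help to show, and whether a side chain carrying an amine would shift the number the same way. Going by these compounds, it is also open whether the step would survive with a carboxylic acid in place of the methyl ester on the same chain.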